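Chloro in place of hydrogen: working notes

The source may report more compounds than this note shows. Statements on the series, on what has been measured and on what is new or still open speak of the compounds shown alone.

Compound 1 `Nc1ccc(-c2nc3cc(F)ccc3s2)cc1` gives 260 nM
Compound 2 `Nc1ccc(-c2nc3ccc(F)cc3s2)cc1Cl` has no result reported

Among the compounds with values here, in a functional assay on T47D cells (Breast, Homo sapiens) for inhibition (on this read-out higher numbers stand for weaker inhibition of growth and lower numbers for stronger inhibition of growth), compound 1 gives 260 nM, the only number available, so its standing cannot yet be judged. Compound 3 `Nc1ccc(-c2nc3cc(F)ccc3s2)cc1Cl` has chloro in place of hydrogen on an aromatic carbon of compound 1, ortho to an amino group (chloro in place of hydrogen on an aromatic carbon). Within the data shown here, no measured step exists for this change, so the expectation is tentative: a lower number in this assay, meaning stronger inhibition of growth, by more than the scatter. The estimated change is an 8.7-fold lower number from compound 1 to compound 3 (0.94 log units; beyond the scatter). Compound 3 is expected near 30 nM, with an estimated range of 3 nM to 250 nM.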

Compound 3, concentration for 50% growth inhibition: 40 nM
Compound 3: the middle estimate sits 1.3-fold (0.12 log units) below what was measured; the measured number falls inside the stated range.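

In this assay, within the data shown here, chloro in place of hydrogen ortho to an amino group gives a 6.5-fold lower number from compound 1 to compound 3 (0.81 log units; beyond the scatter) and so yields the first measured step: this position accepts a chlorine, and the number moves beyond the scatter toward stronger inhibition of growth. No accompanying evidence bears on the origin of this step.

From the compounds shown here alone, whether other groups at this position, such as bromo, methyl or methoxy, give a similar step remains open. Going by these compounds, with no number for compound 2, the effect of moving the fluoro group in the chloro series also remains open.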